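Compound 4: a Bromophenyl Variant Assessed for Cytotoxicity

This account rests on a few compounds, and the source may have more. Where it says the series, first, only, none or still open, it means among the compounds named here.

Three compounds were measured in an ADME assay on HepG2 cells (Homo sapiens) for cytotoxicity, read by MTT assay, with a stated time of 48 h; on this read-out higher numbers stand for lower toxicity in this test and lower numbers for higher toxicity in this test:
compound 1 `CC(=O)OC[C@H]1O[C@H](OC[C@@H](Cn2cc(CN(c3nc(-c4ccc(F)cc4)no3)C3CCCCC3)nn2)OC(C)=O)C=C[C@@H]1OC(C)=O` gives 28.8 ug/mL;
compound 2 `CC(=O)OC[C@H]1O[C@H](OC[C@@H](Cn2cc(CN(c3nc(-c4ccc(C)cc4)no3)C3CCCCC3)nn2)OC(C)=O)C=C[C@@H]1OC(C)=O` gives 36.8 ug/mL;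
compound 3 `CC(=O)OC[C@H]1O[C@H](OC[C@@H](Cn2cc(CN(c3nc(-c4cccc(C)c4)no3)C3CCCCC3)nn2)OC(C)=O)C=C[C@@H]1OC(C)=O` gives 39.2 ug/mL.

Compound 3 does not stand apart from the other two: a 1.1-fold higher number from compound 2 to compound 3 (0.03 log units; within the scatter) and a 1.4-fold higher number from compound 1 to compound 3 (0.13 log units; within the scatter) are both within the scatter, as is a 1.3-fold higher number from compound 1 to compound 2 (0.11 log units; within the scatter). Compound 4 `CC(=O)OC[C@H]1O[C@H](OC[C@@H](Cn2cc(CN(c3nc(-c4ccc(Br)cc4)no3)C3CCCCC3)nn2)OC(C)=O)C=C[C@@H]1OC(C)=O` differs from compound 3 by 4-bromophenyl in place of 3-methylphenyl on an aromatic carbon. Within the data shown here, the steps that bear on this change are the three just given, each an exchange of the substituted phenyl group at the same place, and none of them moved this assay beyond the scatter. Compound 4 is therefore expected to show no step beyond the scatter, a 1.2-fold lower number from compound 3 to compound 4 (0.07 log units; within the scatter). The estimated value of compound 4 in this assay is 33 ug/mL, within 18 ug/mL to 58 ug/mL.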

Compound 4, half-maximal cytotoxic concentration: 47.6 ug/mL
Estimate against measurement, compound 4: 1.4-fold (0.16 log units) below; the measured number falls inside the stated range.
By their numbers in this assay, from the lowest: compounds 1, 2, 3 and 4 (each within the scatter of the next).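

Bromo at the 4-position of the phenyl group extends the series at this place on the ring, and this assay still shows no step beyond the scatter (a 1.2-fold higher number from compound 3 to compound 4 (0.08 log units; within the scatter)). The same holds against the close analogues with methyl (a 1.3-fold higher number from compound 2 to compound 4 (0.11 log units; within the scatter)) and fluoro (a 1.7-fold higher number from compound 1 to compound 4 (0.22 log units; within the scatter)), so all four substituted phenyl groups remain indistinguishable in this test. Nothing available explains these small differences.

The compounds shown carry only fluoro, bromo or methyl on this phenyl group. Going by these compounds, whether an amine or a carboxylic acid there would produce a step beyond the scatter remains open.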